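Sulfonyl aryl swaps and liver microsome clearance in the series

The source may hold more compounds than are shown below. What is called first, only, known or untested is meant among the compounds shown, and "the series" means these compounds.

Among the compounds with values here, compound 3 `O=S(=O)(c1cc(Cl)cc(Cl)c1)c1cnc2cc(F)ccc2c1-c1cccc(F)c1` holds the second highest of the three numbers measured so far in an ADME assay on microsomes from liver (Homo sapiens) for metabolic stability, tested at 2.5 uM; a higher number here means faster removal of the compound, a lower number slower removal: compound 3 gives 0.41 mL/min. Compound 1 `O=S(=O)(c1ccc(F)cc1)c1cnc2cc(F)ccc2c1-c1cccc(F)c1` gives 0.95 mL/min, and a 2.3-fold lower number from compound 1 to compound 3 (0.36 log units; beyond the scatter). Compound 2 `O=S(=O)(c1cc(F)cc(F)c1)c1cnc2cc(F)ccc2c1-c1cccc(F)c1` gives 0.06 mL/min, and a 6.8-fold higher number from compound 2 to compound 3 (0.83 log units; beyond the scatter). Between the other pair, a 16-fold lower number from compound 1 to compound 2 (1.20 log units; beyond the scatter).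

The next step is compound 4 `Cc1ccc(S(=O)(=O)c2cnc3cc(F)ccc3c2-c2cccc(F)c2)cc1F`, where (3-fluoro-4-methylphenyl in place of 3,5-dichlorophenyl on a sulfonyl sulfur). All three steps that bear on the sulfonyl aryl lie beyond the scatter, so a change here is expected to move the number, though the steps run in both directions. Within the data shown here, the 3-fluoro-4-methylphenyl combines one fluorine with a methyl, a pattern no measured compound shares, so the direction is uncertain; the nearest comparison is compound 1, whose 4-fluorophenyl gives the highest value, 0.95 mL/min, and the single fluorine of compound 4 sits in the manner of compound 2, whose value is 0.06 mL/min. A modest upward step is therefore expected, a 1.5-fold higher number from compound 3 to compound 4 (0.17 log units; within the scatter). For compound 4 the estimate is 0.6 mL/min, within 0.2 mL/min to 1.6 mL/min.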

Compound 4, intrinsic clearance in a liver preparation (reported as CLH), per the amount of preparation that the assay uses: 0.41 mL/min
Compound 4: middle estimate off by 1.5-fold (0.17 log units), on the high side; the range from low to high includes it.
By their numbers in this assay, from the lowest: compound 2; then compounds 3 and 4 (each within the scatter of the next); then compound 1.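

In this assay, swapping 3,5-dichlorophenyl for 3-fluoro-4-methylphenyl on the sulfonyl sulfur gives no change at the digits printed from compound 3 to compound 4 (within the scatter), so two aryl groups with no substituent in common cannot be told apart here. Against 3,5-difluorophenyl the step is a 6.8-fold higher number from compound 2 to compound 4 (0.83 log units; beyond the scatter), and against 4-fluorophenyl it is a 2.3-fold lower number from compound 1 to compound 4 (0.36 log units; beyond the scatter), so the three fluorine-bearing aryl groups span the full range of the four values and the presence of fluorine alone does not sort them. No measurement at hand bears on why the values fall this way.

Open, from the compounds shown here alone, is how 4-methylphenyl or unsubstituted phenyl would compare with 3-fluoro-4-methylphenyl. Also open, going by these compounds, is whether an amine or a carboxylic acid on the sulfonyl aryl ring would extend this range.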